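The source may report more compounds than this note shows. Statements on the series, on what has been measured and on what is new or still open speak of the compounds shown alone.

Series notes. Compound 1 `C=C(C)C[N+](C)(C)c1ccccc1O`, compound 2 `C=C(C)C[N+](C)(C)c1ccc(O)cc1` and compound 3 `C=C(C)C[N+](C)(C)c1ccccc1OC` were run in a functional assay with Cavia porcellus as the target; on this read-out lower numbers stand for stronger inhibition and higher numbers for weaker inhibition. In this assay compound 1 gives only the limit > 3000 nM. Compound 2 likewise gives only the limit > 3000 nM. Compound 3 also gives only the limit > 3000 nM, so its standing is no more than a limit. The step from compound 1 to compound 3, methyl in place of hydrogen on an oxygen on an aromatic ring, is a step that the two limits leave unreadable from compound 1 to compound 3; this rests on (the limit of > 3000 nM in this assay, at which 3 of the 3 values shown sit). Compound 4 `COc1ccccc1[N+](C)(C)Cc1ccccc1` differs from compound 3 by phenyl in place of 1-methylethenyl on a saturated chain carbon bound to a nitrogen on an aromatic ring. Going by the values given here, no measured step bears on this change, and the step from compound 3 to compound 4 is expected at a step that the limit leaves unreadable from compound 3 to compound 4. Compound 4 is therefore expected near 6000 nM, in the range 1500 nM to 25000 nM, most likely again only a limit.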

Compound 4, half-maximal inhibitory concentration: > 3000 nM
Compound 4: a limit, no number; the forecaster's own chance of this, stated with the estimate: 70%; the middle value lies beyond the limit too.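

Compound 3 and compound 4 both give only a limit in this assay, so no step can be read for phenyl in place of 1-methylethenyl. The compounds shown leave open which structural change, if any, would bring a value inside the measurable range.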